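The compounds below may be only part of what the source reports. "The series", "measured", "known", "first", "only" and "open" are said of these compounds alone.

Working notes on the series. Compound 3 `CSCC[C@H](NC(=O)CN(c1nc(Cl)nc2[nH]cnc12)C1CC1)C(=O)O` is the reference point here. In a functional assay on the whole organism (Tail, strain ICR) with Mus musculus as the target, in the tail flick test, with a stated time of 150 min, at a dose of 25 umol/kg by the oral route (on this read-out higher numbers stand for a stronger effect at the one dose given and lower numbers for a weaker effect), compound 3 gives 4.14%. The two other measured members are compound 1 `CSCC[C@H](NC(=O)CN(c1nc(Cl)nc2[nH]cnc12)C1CC1)C(=O)OCc1ccccc1`, which in this assay gives 17.6%, and compound 2 `O=C(O)C[C@H](NC(=O)CN(c1nc(Cl)nc2[nH]cnc12)C1CC1)C(=O)O`, which in this assay gives 11.6%. Compound 3 sits at the low end of these three numbers: the step of a number 13.5 percentage points lower from compound 1 to compound 3 (beyond the scatter) lies beyond the scatter, whereas the step of a number 7.5 percentage points lower from compound 2 to compound 3 (within the scatter) stays within it, so compound 2 and compound 3 cannot be separated on this read-out.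

The next member is compound 4 `CC[C@H](C)[C@H](NC(=O)CN(c1nc(Cl)nc2[nH]cnc12)C1CC1)C(=O)O`. Relative to compound 3 the change is sec-butyl in place of 2-(methylsulfanyl)ethyl on a saturated chain carbon bound to an amide-type nitrogen and a carbonyl carbon. For the measured compounds named here, the one measured step that touches this same chain carbon is a number 7.5 percentage points lower from compound 2 to compound 3 (within the scatter), and it was within the scatter. The step of a number 13.5 percentage points lower from compound 1 to compound 3 (beyond the scatter) alters a different position and gives no guidance on the side chain. Going by the values given here, with only one comparable step, and that one flat, the expectation for this assay is no change beyond the scatter, in either direction. The expected step is a number 2.9 percentage points higher from compound 3 to compound 4 (within the scatter). For compound 4 the estimate in this assay is 7%, with a range from 0% to 17%.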

Compound 4, a percentage reported as activity, at one dose (the size of the read-out at that dose, not a potency): 6.71%
Compound 4: the middle estimate sits 0.3 percentage points above what was measured; the range from low to high includes it.
By their numbers in this assay, from the lowest: compounds 3, 4, 2 and 1 (each within the scatter of the next, the first and the last beyond it).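

At the saturated chain carbon bound to an amide-type nitrogen and a carbonyl carbon, this assay now covers three side chains on the free acid. Sec-butyl in place of 2-(methylsulfanyl)ethyl gives a number 2.6 percentage points higher from compound 3 to compound 4 (within the scatter) and sec-butyl in place of carboxymethyl gives a number 4.9 percentage points lower from compound 2 to compound 4 (within the scatter) so that an all-carbon branched chain cannot be separated from either the sulfur-bearing chain or the carboxyl-bearing chain on this read-out. Nothing available bears on why these exchanges leave the read-out flat.

On these data alone, it remains open whether an amine, a phenyl ring or a longer chain at this carbon would give a step beyond the scatter. For the compounds shown here, it is also open whether the only step beyond the scatter around compound 3, a number 13.5 percentage points lower from compound 1 to compound 3 (beyond the scatter) with hydrogen in place of benzyl on the oxygen next to the carbonyl group, would carry over to the sec-butyl side chain of compound 4.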